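From 2-fluorobenzyl to isopentyl: a half-life at the limit

A few compounds are considered here, and "the series" means these few. Any claim that something is new, unique, unknown or untested is made for them only; others in the source may bear on it.

Measured in an in vitro ADME assay on microsomes from liver (Homo sapiens) for metabolic stability, tested at 1 uM; a lower number here means that the compound disappears faster, a higher number that the compound lasts longer:
- compound 1 `CS(=O)(=O)Nc1ccc2c(c1)S(=O)(=O)N=C(C1=C(O)[C@@H]3[C@H]4CC[C@H](C4)[C@@H]3N(Cc3ccccc3F)C1=O)N2` gives > 1 h
- compound 2 `CS(=O)(=O)Nc1ccc2c(c1)S(=O)(=O)N=C(C1=C(O)[C@@H]3[C@@H]4CC[C@@H](C4)[C@@H]3N(Cc3ccccc3F)C1=O)N2` gives > 1 h

Compound 2 stands at > 1 h, which is a limit and not a number. That reading is shared, as the limit of > 1 h in this assay, at which 2 of the 2 values shown sit, shows. Among the compounds with values here, the only measured step is a step that the two limits leave unreadable from compound 1 to compound 2, and it reflects (the fact that compounds 1 and 2 differ only in the configuration as drawn), so it says nothing about the side chain. Compound 3 `CC(C)CCN1C(=O)C(C2=NS(=O)(=O)c3cc(NS(C)(=O)=O)ccc3N2)=C(O)[C@@H]2[C@@H]3CC[C@@H](C3)[C@@H]21` carries isobutyl in place of 2-fluorophenyl on a saturated chain carbon bound to an amide-type nitrogen in a ring, with isobutyl in place of 2-fluorophenyl. Within the data shown here, no measured step gives a size or direction for this change, so none beyond the scatter is expected: a number no higher from compound 2 to compound 3 (the limit leaves the size open). The half-life of compound 3 is estimated at 1 h, within an expected range of 0.5 h to 2 h.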

Compound 3, half-life: 0.3 h
For compound 3 the middle estimate is 3.3-fold (0.52 log units) above the measured one, outside the stated range (below it).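

At this position, on a saturated chain carbon bound to an amide-type nitrogen in a ring, isobutyl in place of 2-fluorophenyl gives an at least 3.3-fold lower number from compound 2 to compound 3 (0.52 log units; beyond the scatter). This is the only readable step shown, since the step between the two configurations cannot be read, and compound 3 is the only compound with a half-life that is a number. The full size of the step stays open because compound 2 sits at a limit: the limit of > 1 h in this assay, at which 2 of the 3 values shown sit.

The compounds shown do not settle whether the aromatic ring or the fluorine matters for the half-life. Going by these compounds, how an unsubstituted benzyl or a cyclohexyl group would behave at this position also stays open.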